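Swapping a Sulfonamide for a Pyrazole: Solubility Expectations

This account rests on a few compounds, and the source may have more. Where it says the series, first, only, none or still open, it means among the compounds named here.

Of the compounds shown here, three built on a shared core have been measured in a physicochemical assay for solubility, read by nephelometry, in phosphate buffer, measured as kinetic solubility, at pH 6.5; a higher number here means a more soluble compound, a lower number a less soluble compound. Compound 1 `CNS(=O)(=O)c1ccc(-c2cnc(N)c(-c3ccc(OC)nc3)c2)cc1` gives 12.5 ug/mL. Compound 2 `COc1ccc(-c2cc(-c3ccc(S(C)(=O)=O)cc3C(F)(F)F)cnc2N)cn1` gives 12.5 ug/mL, level with compound 1 at the digits recorded, and together these two sit at the lowest of the three numbers. Compound 3 `COc1ccc(-c2cnc(N)c(-c3ccc(OC)nc3)c2)cn1` gives 25 ug/mL, a somewhat higher number than compound 1, though the gap between compound 1 and compound 3 is within the scatter of repeated measurements, so no real order between them can be claimed.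

Compound 4 `COc1ccc(-c2cc(-c3ccc(-n4cccn4)cc3)cnc2N)cn1` has not yet been measured. It differs from compound 1 in one place: 1H-pyrazol-1-yl in place of methylsulfamoyl on an aromatic carbon. Going by the values given here, no pair of measured compounds shows this change, so the direction and size of the step have to be judged from the structures and from the numbers at hand. The three measured numbers lie close together, and nothing among them points to a large move in either direction.

In this assay compound 4 is expected to come out somewhat lower than the measured compounds. The expected step is a 2.1-fold lower number from compound 1 to compound 4 (0.32 log units; beyond the scatter), modest rather than large. Compound 4 is estimated at 6 ug/mL, with a range from 2 ug/mL to 25 ug/mL.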

Compound 4, solubility: 3.1 ug/mL
The estimate for compound 4 lay 1.9-fold (0.29 log units) above the measured number; low and high end bracket the measured number.
By their numbers in this assay, from the lowest: compound 4; then compounds 1, 2 and 3 (each within the scatter of the next).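

In this assay, putting 1H-pyrazol-1-yl in place of methylsulfamoyl on an aromatic carbon, para to a large group, gives a 4.0-fold lower number from compound 1 to compound 4 (0.61 log units; beyond the scatter) and is the only step shown at this position. Going by these compounds alone, the result shows that the number can move beyond the scatter when this one group changes, even though the three earlier compounds sat close together and offered no step to read. By the structural count, the swap keeps the number of heavy atoms and hydrogen-bond acceptors, while it removes the hydrogen-bond donor and adds a five-membered aromatic ring, but no measurement here links the step to either difference.

As far as these compounds go, with only one replacement to read, it remains open how a different group at this position, such as a carboxylic acid or a simple amine, would move the number in this assay and whether it would fall on the higher or the lower side of compound 1. Also open, from the compounds shown here alone, is whether the same swap would give a step of similar size on another core.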